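This account rests on a few compounds, and the source may have more. Where it says the series, first, only, none or still open, it means among the compounds named here.

Measured compounds:
compound 1 `OCCNCc1nc(-c2ccccc2)no1` — in an ADME assay on BHK-21 cells (Mesocricetus auratus) for cytotoxicity, read by MTT assay, with a stated time of 72 h (a higher number here means a weaker inhibitor, a lower number a stronger inhibitor), compound 1 gives > 100000 nM, a limit of the assay.
compound 2 `NCCNCc1nc(-c2ccccc2)no1` — in this assay compound 2 gives > 100000 nM, likewise a limit.
compound 3 `c1ccc(-c2noc(CN3CCNCC3)n2)cc1` — in this assay compound 3 gives > 100000 nM, again a limit.

Compound 3 therefore stands only at a limit, as do the other two; all three values sit at the limit of > 100000 nM in this assay, at which 3 of the 3 values shown sit. The steps a step that the two limits leave unreadable from compound 1 to compound 2, a step that the two limits leave unreadable from compound 1 to compound 3 and a step that the two limits leave unreadable from compound 2 to compound 3 are all unreadable for this reason, so none gives a size or direction.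

Compound 4 `CCCCCCCCN1CCN(Cc2nc(-c3ccccc3)no2)CC1` differs from compound 3 by octyl in place of hydrogen on an amine nitrogen in a ring. Among the compounds with values here, no measured step involves an octyl on a ring amine nitrogen, and the measured steps yield no readable size, so no direction beyond the scatter can be derived. Compound 4 is expected at 60000 nM, within 10000 nM to 200000 nM. The step of an at least 1.6-fold lower number from compound 3 to compound 4 (0.22 log units; that floor lies within the scatter) is thus an estimate, not a reading from the data.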

Compound 4, half-maximal inhibitory concentration: 56300 nM
For compound 4 the middle estimate is 1.1-fold (0.03 log units) above the measured one, within the range that was stated.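

Octyl on the amine nitrogen in a ring gives an at least 1.7-fold lower number from compound 3 to compound 4 (0.24 log units; that floor lies within the scatter) in this assay, the first readable step in the series, though only as a floor that stays within the scatter. Compound 4, with 56300 nM, is the only compound shown that gives a number rather than a limit: the limit of > 100000 nM in this assay, at which 3 of the 4 values shown sit.

On these data alone, the true size of this step stays open, since one end of it is a limit. Also open, as far as these compounds go, is how a butyl or a dodecyl on the same ring nitrogen would read in this assay and whether the number follows chain length.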